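The compounds below may be only part of what the source reports. "The series", "measured", "known", "first", "only" and "open" are said of these compounds alone.

Measured so far in an ADME assay on microsomes from liver (Rattus norvegicus) for metabolic stability, read by LC-MS, using NADPH, with a stated time of 10 min, tested at 0.1 uM; a lower number here means slower removal, a higher number faster removal of the compound:
compound 1 `O=C(NCCCCn1cccn1)c1cccc(C2SCC(=O)N2c2ccccn2)c1` gives 506 mL.min-1.g-1
compound 2 `O=C(NCCCCc1ccccc1)c1cccc(C2SCC(=O)N2c2ccccn2)c1` gives 1480 mL.min-1.g-1
compound 3 `CC(F)(F)c1cccc(N2C(=O)CSC2c2cccc(C(=O)NCCCCc3ccccc3)c2)c1` gives 2320 mL.min-1.g-1

Compound 1 stands lowest of the three, and even its nearest neighbour, compound 2, lies beyond the scatter from it. The next compound, compound 4 `O=C(NCCCCn1cccn1)c1cccc(C2SCC(=O)N2c2cc(F)ccn2)c1`, differs from compound 1 in one place. The change is fluoro in place of hydrogen on an aromatic carbon and, in words, fluoro in place of hydrogen on an aromatic carbon, which turns pyridin-2-yl into 4-fluoropyridin-2-yl.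

Within the data shown here, no measured step makes this exchange. The step of a 2.9-fold higher number from compound 1 to compound 2 (0.47 log units; beyond the scatter) concerns the saturated chain, not the group that changes here, so it bears on the question only loosely. The step of a 1.6-fold higher number from compound 2 to compound 3 (0.20 log units; within the scatter) is closer, as it replaces that same group on an amide-type nitrogen in a ring, and this far larger exchange stayed within the scatter. A single fluoro is therefore expected to give no step beyond the scatter in this assay in either direction. The expected step is a 1.1-fold higher number from compound 1 to compound 4 (0.04 log units; within the scatter) and would lie within the scatter. For compound 4 the estimated value is 560 mL.min-1.g-1 with an expected range from 290 mL.min-1.g-1 to 1080 mL.min-1.g-1 in this measurement.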

Compound 4, intrinsic clearance in microsomes: 1200 mL.min-1.g-1
Estimate against measurement, compound 4: 2.1-fold (0.33 log units) below; measured number outside the range, above it.
By their numbers in this assay, from the lowest: compound 1; then compounds 4, 2 and 3 (each within the scatter of the next).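

In this assay, fluoro in place of hydrogen on the aromatic carbon opposite the ring nitrogen gives a 2.4-fold higher number from compound 1 to compound 4 (0.38 log units; beyond the scatter), showing that this one position on the pyridin-2-yl group can shift the number beyond the scatter on its own. The earlier exchange at the amide-type nitrogen in a ring, a 1.6-fold higher number from compound 2 to compound 3 (0.20 log units; within the scatter), was far larger in heavy atoms yet stayed within the scatter, so among these compounds the size of the exchange does not track the size of the step, although that earlier step was read on the phenyl chain and this one on the 1H-pyrazol-1-yl chain. Nothing shown here gives a measured reason for the rise that comes with 4-fluoropyridin-2-yl.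

The compounds shown leave open whether chloro, methoxy or a nitrile on this same carbon would give a step of similar size, and whether fluoro on another carbon of the ring would do so. They also leave open whether the step from pyridin-2-yl to 4-fluoropyridin-2-yl would carry over to the phenyl chain of compound 2.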